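The source may report more compounds than this note shows. Statements on the series, on what has been measured and on what is new or still open speak of the compounds shown alone.

Working notes on the series. Two compounds built on the shared core have been run in a functional assay on MCF7 cells (Homo sapiens) for cytotoxicity, read by MTT assay, with a stated time of 24 h; a lower number here means a stronger inhibitor, a higher number a weaker inhibitor. Compound 1 `COc1ccc(C2CC(=O)c3cc(OC)c(OC)c(OC)c32)c(OC)c1OC` returns only a limit: in this assay compound 1 gives >= 250000 nM, which is a limit of the assay and not a number. Among the compounds with values here, compound 2 `COc1cc(C2CC(=O)c3cc(OC)c(OC)c(OC)c32)cc(OC)c1OC` supplies the one actual number: in this assay compound 2 gives 2200 nM. Within the data shown here, compound 2 therefore stands as the only measured value in the set, the remaining entry sitting at the limit of >= 250000 nM in this assay, at which 1 of the 2 values shown sits. Among the measured compounds shown here, no step between two measured compounds is available to calibrate against.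

Compound 3 `COc1cc2c(cc1OC)C(c1cc(OC)c(OC)c(OC)c1)CC2=O` differs from compound 2 by hydrogen in place of methoxy on an aromatic carbon on an aromatic carbon of the six-membered ring within the fused two-ring system. For the measured compounds named here, with no measured step to lean on, the step from compound 2 to compound 3 is expected to be modest, toward weaker inhibition, roughly a 2.7-fold higher number from compound 2 to compound 3 (0.44 log units; beyond the scatter). Compound 3 is accordingly estimated at 6000 nM with a range from 1500 nM to 30000 nM.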

Compound 3, half-maximal inhibitory concentration: >= 250000 nM
Compound 3 was reported as a limit (the forecaster's own chance of this, stated with the estimate: 15%); at least 41-fold (1.61 log units) between middle value and limit.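

Hydrogen in place of methoxy on an aromatic carbon of the fused two-ring system is the first single-place change in the series, and in this assay it gives an at least 110-fold higher number from compound 2 to compound 3 (2.05 log units; beyond the scatter). As far as these compounds go, compound 3 gives >= 250000 nM, which is a limit of the assay and not a number, so the true size of the step stays unknown. This position is therefore far from indifferent to the change, and compound 2 remains the only compound with an actual number: the limit of >= 250000 nM in this assay, at which 2 of the 3 values shown sit.

Still open, from the compounds shown here alone, is whether any group other than methoxy keeps a measurable value at this carbon. A hydroxyl, an ethoxy group or a fluorine there would show whether the oxygen alone or the whole methoxy group is what counts.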